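Adding a methyl to the isopropyl end of compound 1

The source may hold more compounds than are shown below. What is called first, only, known or untested is meant among the compounds shown, and "the series" means these compounds.

In a functional assay on T47D cells (Homo sapiens) for antiproliferative activity, read by sulforhodamine B assay, with a stated time of 48 h (on this read-out higher numbers stand for weaker inhibition of growth and lower numbers for stronger inhibition of growth), compound 1 `CCCCCCCCCCCCCCC[C@@H](O)[C@@H](N)C(C)C` gives 18000 nM, compound 2 `CCCCCCCCC[C@@H](O)[C@@H](N)C(C)C` gives 17000 nM and compound 3 `CCCCCCCCC[C@@H](O)[C@@H](N)[C@@H](C)O` gives 16000 nM. All three numbers lie within the scatter of one another, so compound 1 stands in a flat set with no separation among its neighbours.

Compound 4 `CCCCCCCCCCCCCCC[C@@H](O)[C@@H](N)[C@@H](C)CC` differs from compound 1 as follows: methyl in place of hydrogen on a saturated chain carbon, three bonds along the chain from an amine nitrogen. Cut one bond further out, this reads isopropyl to sec-butyl, and the long chain of compound 1 stays as it is.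

Within the data shown here, two measured steps bear on this change. The closer one alters the same end of the molecule, with 1-hydroxyethyl in place of isopropyl: a 1.1-fold lower number from compound 2 to compound 3 (0.03 log units; within the scatter). The other replaces hexyl with hydrogen on the long chain: a 1.1-fold lower number from compound 1 to compound 2 (0.02 log units; within the scatter). Neither step leaves the scatter in this assay. Among the measured compounds shown here, no measured pair shows the added methyl on its own, so the expectation rests on this flat behaviour alone.

No step beyond the scatter is expected, and the estimated step is a 1.1-fold lower number from compound 1 to compound 4 (0.02 log units; within the scatter).

For compound 4 the expected value is 17000 nM, with an estimated range of 10000 nM to 28000 nM.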

Compound 4, concentration for 50% growth inhibition: 17000 nM
Compound 4: middle estimate and measured number agree at the digits printed; the range from low to high includes it.
By their numbers in this assay, from the lowest: compounds 3, 2, 4 and 1 (each within the scatter of the next).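

In this assay, among these compounds, the added methyl gives a first reading of a carbon-only change at this end with the long chain of compound 1 kept in place: a 1.1-fold lower number from compound 1 to compound 4 (0.02 log units; within the scatter). The earlier change at this end, 1-hydroxyethyl in place of isopropyl, was read only on the shorter chain of compound 2, so isopropyl to sec-butyl extends the flat picture to the longer chain. Nothing measured here accounts for the absence of a step beyond the scatter at this position.

The compounds shown leave open whether any group at this end separates from the set, for example a phenyl ring, a carboxylic acid or a longer chain in place of the sec-butyl group of compound 4. Also open, from the compounds shown here alone, are the opposite configuration at the carbon carrying the new methyl and the combination of sec-butyl with the shorter chain of compound 2, so the flat behaviour holds only for these four compounds.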